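From Neopentyloxy to Butylsulfanyl: an Expected Step

The source may hold more compounds than are shown below. What is called first, only, known or untested is meant among the compounds shown, and "the series" means these compounds.

Compound 3 `CC(C(=O)NCc1ccc(C(C)(C)C)cc1OCC(C)(C)C)c1ccc(NS(C)(=O)=O)c(F)c1` gives the highest number of the three measured compounds in an assay on cells for antagonist activity at transient receptor potential cation channel subfamily V member 1 (Homo sapiens), read by FLIPR and calcium flux, with a stated time of 6 min (a higher number here means a weaker inhibitor, a lower number a stronger inhibitor), namely 3.8 nM. Compound 1 `CC1CCN(c2cc(C(C)(C)C)ccc2CNC(=O)C(C)c2ccc(NS(C)(=O)=O)c(F)c2)CC1` gives 0.7 nM, and compound 2 `CCCCOc1cc(C(C)(C)C)ccc1CNC(=O)C(C)c1ccc(NS(C)(=O)=O)c(F)c1` gives 1.4 nM; a 2.0-fold higher number from compound 1 to compound 2 (0.30 log units; within the scatter), whereas a 5.4-fold higher number from compound 1 to compound 3 (0.73 log units; beyond the scatter). Compound 4 `CCCCSc1cc(C(C)(C)C)ccc1CNC(=O)C(C)c1ccc(NS(C)(=O)=O)c(F)c1` differs from compound 3 by butylsulfanyl in place of neopentyloxy on an aromatic carbon. Among the compounds with values here, the measured step that bears most directly on this change is a 2.7-fold higher number from compound 2 to compound 3 (0.43 log units; beyond the scatter): compound 4 carries a butyl chain like compound 2, but joined through sulfur rather than oxygen, and no measured pair shows what that sulfur-for-oxygen exchange does on its own. A modest move towards a lower number is therefore expected, a 1.9-fold lower number from compound 3 to compound 4 (0.28 log units; within the scatter). Compound 4 is estimated at 2 nM, within a range from 0.6 nM to 7 nM.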

Compound 4, inhibition constant: 6.7 nM
The estimate for compound 4 lay 3.4-fold (0.53 log units) below the measured number, and the stated range covers the measured number.
By their numbers in this assay, from the lowest: compounds 1 and 2 (each within the scatter of the next); then compounds 3 and 4 (each within the scatter of the next).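

In this assay, butylsulfanyl in place of neopentyloxy gives a step that cannot be told from no change (a 1.8-fold higher number from compound 3 to compound 4 (0.25 log units; within the scatter)). Within the data shown here, the clearer reading comes with the butyl chain held constant, where sulfur in place of oxygen as the link to the ring gives the first view of that exchange (a 4.8-fold higher number from compound 2 to compound 4 (0.68 log units; beyond the scatter)), while replacing 4-methylpiperidin-1-yl with butylsulfanyl gives the widest step at this position so far (a 9.6-fold higher number from compound 1 to compound 4 (0.98 log units; beyond the scatter)). No measurement available here explains these steps. Going by these compounds, it remains open whether neopentylsulfanyl would repeat the step seen between the two oxygen-linked chains, and what butylsulfonyl would give at this position.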